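The source may hold more compounds than are shown below. What is called first, only, known or untested is meant among the compounds shown, and "the series" means these compounds.

Measured in a functional assay on a cell-free system (plasma, Homo sapiens), with a stated time of 3 min; a higher number here means a weaker inhibitor, a lower number a stronger inhibitor:
- compound 1 `O=C(NCc1cc(Cl)ccc1-n1cnnn1)[C@@H]1[C@H]2C[C@H]2CN1C(=O)[C@H](O)c1ccccc1`: 960 nM
- compound 2 `COC(C)(C)[C@@H](O)C(=O)N1C[C@H]2C[C@H]2[C@H]1C(=O)NCc1cc(Cl)ccc1-n1cnnn1`: 1000 nM
- compound 3 `CC1(C[C@@H](O)C(=O)N2C[C@H]3C[C@H]3[C@H]2C(=O)NCc2cc(Cl)ccc2-n2cnnn2)CC1`: 500 nM

The three values lie within the scatter of one another, so compound 3, at 500 nM, cannot be separated from compound 1 or compound 2. The next compound is compound 4 `O=C(NCc1cc(Cl)ccc1-n1cnnn1)[C@@H]1[C@@H]2C[C@@H]2CN1C(=O)[C@H](O)c1ccccc1`. Going to it from compound 3, phenyl takes the place of (1-methylcyclopropyl)methyl on a saturated chain carbon bound to a carbonyl carbon and an oxygen on a saturated carbon: phenyl in place of (1-methylcyclopropyl)methyl on a saturated chain carbon bound to a carbonyl carbon and an oxygen on a saturated carbon. The drawn structures also show a different spatial arrangement within the shared core, and compound 4 differs from compound 1 in that arrangement as well. Among the measured compounds shown here, no measured compound carries it.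

For the measured compounds named here, the one measured step at this place is a 2.0-fold lower number from compound 2 to compound 3 (0.30 log units; within the scatter), so exchanging this group has so far produced no clear change. Compound 1, which also carries phenyl, gives 960 nM, and this sets the expectation for compound 4. In this assay the expected change is a 2.4-fold higher number from compound 3 to compound 4 (0.38 log units; beyond the scatter), a small estimated rise that rests on that single value. From the compounds shown here alone, for compound 4 the estimated value is 1200 nM, with an expected range of 250 nM to 6000 nM, kept wide since the core arrangement is untested.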

Compound 4, half-maximal inhibitory concentration: 700 nM
Compound 4: the middle estimate sits 1.7-fold (0.23 log units) above what was measured, and the stated range covers the measured number.
By their numbers in this assay, from the lowest: compounds 3, 4, 1 and 2 (each within the scatter of the next).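

Among the compounds shown here, the different arrangement within the shared core, carried by no earlier compound, can now be read on its own, with phenyl held constant on both sides of the comparison: the fact that compounds 1 and 4 differ only in the configuration as drawn. In this assay the step is a 1.4-fold lower number from compound 1 to compound 4 (0.14 log units; within the scatter), so swapping the two drawn stereocentres gives no clear change with phenyl in this place. The steps of a 1.4-fold higher number from compound 3 to compound 4 (0.15 log units; within the scatter) and a 1.4-fold lower number from compound 2 to compound 4 (0.15 log units; within the scatter) are also within the scatter, but each combines the exchange of groups on the saturated chain carbon with the change in the core, so neither shows the effect of the group exchange alone.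

It remains open whether an amine or a carboxylic acid on this saturated chain carbon, bound to a carbonyl carbon and an oxygen on a saturated carbon, would give a number beyond the scatter of the four compounds shown. From the compounds shown here alone, it is also open whether the core arrangement of compound 4 would leave the number just as unchanged with (1-methylcyclopropyl)methyl or 1-methoxy-1-methylethyl in place of phenyl.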